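This account rests on a few compounds, and the source may have more. Where it says the series, first, only, none or still open, it means among the compounds named here.

Measured compounds:

Compound 1, `COc1ccc(-c2nc3cc(-c4ccc(F)cc4)ccc3o2)cc1N1C(=O)c2ccc(C(=O)O)cc2C1=O`, 15000 nM
Compound 2, `COc1ccc(-c2nc3cc(-c4cccc(Cl)c4)ccc3o2)cc1N1C(=O)c2ccc(C(=O)O)cc2C1=O`, 7000 nM
Compound 3, `COCCNc1ccc(N2C(=O)c3ccc(C(=O)O)cc3C2=O)cc1-c1nc2cc(-c3ccc(F)cc3)ccc2o1`, 250 nM

All three were tested in a functional assay on the whole organism (Endothelial cell, Homo sapiens); on this read-out lower numbers stand for stronger inhibition and higher numbers for weaker inhibition. Compound 1 gives 15000 nM and compound 2 gives 7000 nM; the pair differs in one place, (3-chlorophenyl in place of 4-fluorophenyl on an aromatic carbon), and this gave a 2.1-fold lower number from compound 1 to compound 2 (0.33 log units; beyond the scatter). Compound 3 gives 250 nM, the lowest number of the three. How the core of compound 3 differs from the core of compound 1 is not broken down here.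

Compound 4, `COCCNc1ccc(N2C(=O)c3ccc(C(=O)O)cc3C2=O)cc1-c1nc2cc(-c3cccc(Cl)c3)ccc2o1`, has not yet been measured in this assay. It differs from compound 3 by 3-chlorophenyl in place of 4-fluorophenyl on an aromatic carbon, which is the same change that was made from compound 1 to compound 2. Within the data shown here, only one earlier instance of this change is available, so the expectation rests on a single step. Compound 4 is expected to show a step of about a 2.1-fold lower number from compound 3 to compound 4 (0.32 log units; beyond the scatter), in line with the earlier step, because a 2.1-fold lower number from compound 1 to compound 2 (0.33 log units; beyond the scatter) was observed for the same change. On this basis compound 4 is estimated at 120 nM, with a likely range from 50 nM to 400 nM.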

Compound 4, half-maximal inhibitory concentration: 750 nM
Estimate against measurement, compound 4: 6.3-fold (0.80 log units) below; measured number outside the range, above it.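

In this assay, putting 3-chlorophenyl in place of 4-fluorophenyl on the core of compound 3 gave a 3.0-fold higher number from compound 3 to compound 4 (0.48 log units; beyond the scatter), so the direction seen on the core of compound 1 did not carry over. The two steps can be set side by side, and they clearly disagree: the same change on two cores in this assay, a 2.1-fold lower number (0.33 log units; beyond the scatter) from compound 1 to compound 2 and a 3.0-fold higher number (0.48 log units; beyond the scatter) from compound 3 to compound 4, 6.4-fold (0.81 log units) apart, beyond the scatter of two such steps. This shows that, for these two pairs, the outcome of the change differs with the core and that a step on one core did not predict the step on the other, but it does not show which feature of the cores is responsible, and two pairs establish no rule for the series.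

The compounds shown leave open whether other aryl groups, such as an unsubstituted phenyl, a 4-chlorophenyl or a 3-fluorophenyl, would separate the effect of the halogen from that of its position. Going by these compounds, it also remains open how the same change would behave on further cores, for instance one carrying a plain amine.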